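Trading phenyl for 2-fluorobenzyl on the nitrogen

The source may hold more compounds than are shown below. What is called first, only, known or untested is meant among the compounds shown, and "the series" means these compounds.

In an ADME assay on C8166 cells (Homo sapiens) for cytotoxicity, read by MTT assay (a higher number here means that more compound is tolerated, a lower number that less compound is tolerated), compound 1 (`O=C(O)c1cn(-c2ccccc2)c2ccc(Cc3cccc(Cl)c3F)c(O)c2c1=O`) gives 388000 nM. Compound 2 (`Cc1ccc(Cn2cc(C(=O)O)c(=O)c3c(O)c(Cc4cccc(Cl)c4F)ccc32)cc1`) gives 256000 nM, within the scatter of compound 1, so these two share the top of this small set. Compound 3 (`O=C(O)c1cn(Cc2ccccc2F)c2ccc(Cc3ccccc3F)c(O)c2c1=O`) gives a clearly lower 67100 nM. Compound 4 (`O=C(O)c1cn(Cc2ccccc2F)c2ccc(Cc3cccc(Cl)c3F)c(O)c2c1=O`) differs from compound 1 at one place: 2-fluorobenzyl in place of phenyl on an aromatic nitrogen. Going by the values given here, the one measured step at this place, a 1.5-fold lower number from compound 1 to compound 2 (0.18 log units; within the scatter), stays within the scatter. Compound 3, at 67100 nM, carries the same 2-fluorobenzyl there but also differs elsewhere, so it is only a loose guide. A moderately lower number is therefore expected in this assay, and the expected step is a 2.3-fold lower number from compound 1 to compound 4 (0.36 log units; beyond the scatter). For compound 4 the estimate is 170000 nM, with an expected range of 70000 nM to 380000 nM.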

Compound 4, half-maximal cytotoxic concentration: 44900 nM
For compound 4 the middle estimate is 3.8-fold (0.58 log units) above the measured one; measured number outside the range, below it.
By their numbers in this assay, from the lowest: compounds 4 and 3 (each within the scatter of the next); then compounds 2 and 1 (each within the scatter of the next).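

On the aromatic nitrogen in this assay, the choice of group proves to matter more than the earlier 4-methylbenzyl step suggested: 2-fluorobenzyl in place of phenyl gives a clear drop (an 8.6-fold lower number from compound 1 to compound 4 (0.94 log units; beyond the scatter)). The drop also appears within the benzyl series, where 2-fluorophenyl replaces 4-methylphenyl on the saturated chain carbon (a 5.7-fold lower number from compound 2 to compound 4 (0.76 log units; beyond the scatter)), so the ring's substituents count here. Adding the chloro on the other aromatic ring stays within the scatter (a 1.5-fold lower number from compound 3 to compound 4 (0.17 log units; within the scatter)). Going by these compounds, whether an amine or a longer chain on that nitrogen would fit this picture remains open. Nothing measured here explains the gap.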